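The source may report more compounds than this note shows. Statements on the series, on what has been measured and on what is new or still open speak of the compounds shown alone.

Compound 1 `CC[C@@H](Nc1c(C#N)c(-c2ccc(-c3cccc(Cl)c3F)cc2)nc2cnccc12)C(N)=O` has had its lipophilicity measured in a physicochemical assay for lipophilicity, read by HPLC, at pH 7.5 (on this read-out lower numbers stand for lower lipophilicity and higher numbers for higher lipophilicity), where compound 1 gives 3.1. That is the highest of the three numbers seen so far: compound 2 `CCOc1ccccc1-c1ccc(-c2nc3cnccc3c(C[C@H](C)C(=O)O)c2C#N)cc1` gives 2.2, and compound 3 `CC[C@@H](Nc1c(C#N)c(-c2ccc(-c3cccc(Cl)c3F)cc2)nc2cnccc12)C(=O)O` gives 2.2. For the measured compounds named here, the only measured single-point step, a number 0.90 log units lower from compound 1 to compound 3 (beyond the scatter), alters the carbonyl end of the side chain and not any aromatic ring. Compound 4 `CC[C@@H](Nc1c(C#N)c(-c2ccc(-c3ccccc3C)cc2)nc2cnccc12)C(N)=O` keeps everything of compound 1 apart from one ring: 2-methylphenyl in place of 3-chloro-2-fluorophenyl on an aromatic carbon. Going by the values given here, no measured step touches this ring, so the expectation rests on the exchange of 3-chloro-2-fluorophenyl for 2-methylphenyl alone. A small downward step is expected, a number 0.30 log units lower from compound 1 to compound 4 (within the scatter). Compound 4 is therefore estimated at 2.8, between 2.4 and 3.2.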

Compound 4, distribution coefficient: 3
Compound 4: the middle estimate sits 0.20 log units below what was measured; measured number inside the range.
By their numbers in this assay, from the lowest: compounds 2 and 3 (each within the scatter of the next); then compounds 4 and 1 (each within the scatter of the next).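

Swapping 3-chloro-2-fluorophenyl for 2-methylphenyl on this aromatic carbon gives a number 0.10 log units lower from compound 1 to compound 4 (within the scatter) in this assay. For this one pair, then, exchanging the fluorine and chlorine pattern for a methyl group does not separate the two numbers, unlike the earlier step at the carbonyl end of the side chain, which lay beyond the scatter. Nothing available explains this result. From the compounds shown here alone, a pyridine ring or a phenyl ring carrying an amine at this place remains open. So does whether this ring exchange would give a similar step on the carboxylic acid, compound 3.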